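Truncating the ether tail of an inactive pyrrolidinone amide

A few compounds are considered here, and "the series" means these few. Any claim that something is new, unique, unknown or untested is made for them only; others in the source may bear on it.

Measured so far in an assay on HEK293 cells for inhibition of Ataxin-2 (Mus musculus), read by fluorescence and Amplex Red; a lower number here means a stronger inhibitor, a higher number a weaker inhibitor:
compound 1 `COC(=O)c1ccc(COc2ccc(CNC(=O)[C@@H]3CCC(=O)N3Cc3ccccc3)cc2)cc1`: > 5000 nM
compound 2 `O=C(O)c1ccc(COc2ccc(CNC(=O)[C@@H]3CCC(=O)N3Cc3ccc(Br)cc3)cc2)cc1`: > 5000 nM
compound 3 `O=C(NCc1ccc(OCc2ccc(-c3nn[nH]n3)cc2)cc1)[C@@H]1CCC(=O)N1Cc1ccc(F)cc1`: > 5000 nM.

For compound 3 the value is a limit of this assay, not a number. Among the compounds with values here, the same holds for compound 2, and for compound 1, so that the limit of > 5000 nM in this assay, at which 3 of the 3 values shown sit, is all the three measured compounds show, and no step between them can be sized. Compound 4 `O=C(NCc1ccc(O)cc1)[C@@H]1CCC(=O)N1Cc1ccccc1` differs from compound 1 in one place: hydrogen in place of 4-(methoxycarbonyl)benzyl on an oxygen on an aromatic ring. Within the data shown here, with no measured step to lean on, the shared core of compound 1 gives no sign of inhibition, and compound 4 keeps that core while losing the tail. Compound 4 is therefore expected to show a step that the limit leaves unreadable from compound 1 to compound 4, which is none beyond the scatter. The estimate for compound 4 is 8000 nM, expected to fall between 3000 nM and 30000 nM, most likely reported again as a limit.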

Compound 4, half-maximal inhibitory concentration: > 5000 nM
Compound 4: no number, only a limit (the forecaster's own chance of this, stated with the estimate: 85%); the middle value lies beyond the limit too.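

Within the data shown here, compound 1 and compound 4 both give only limits, not numbers, so no step between them can be read: the limit of > 5000 nM in this assay, at which 4 of the 4 values shown sit. The compounds shown leave open which change to the shared core, if any, would give a measurable value in this assay.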